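The source may hold more compounds than are shown below. What is called first, only, known or untested is meant among the compounds shown, and "the series" means these compounds.

Values so far in an ADME assay on a cell-free system (plasma, Homo sapiens) for metabolic stability, read by LC-MS; on this read-out higher numbers stand for a longer-lived compound and lower numbers for a shorter-lived compound
- compound 1 `NCc1ccc(C(=O)Nc2ccncc2F)cc1-c1cccc(C(=O)Oc2ccccc2)c1` gives 0.117 h
- compound 2 `NCc1ccc(C(=O)Nc2ccncc2)cc1-c1cccc(C(=O)OCc2ccccc2)c1` gives 1.07 h

Compound 1 stands lowest of the two numbers, and the gap up to compound 2 lies beyond the scatter. Compound 3 `CC(C)OCCOC(=O)c1cccc(-c2cc(C(=O)Nc3ccncc3F)ccc2CN)c1` has not yet been measured. It keeps the rest of compound 1 and carries 2-isopropoxyethyl in place of phenyl on an oxygen next to a carbonyl group. Within the data shown here, no measured pair isolates this change, and compounds 1 and 2 differ in more than one place, so the expectation is tentative. A rise beyond the scatter in this assay is expected, with compound 2 at 1.07 h as the only other reference. The estimated change is an 8.5-fold higher number from compound 1 to compound 3 (0.93 log units; beyond the scatter) on this reading. Compound 3 is expected at 1 h within an estimated range of 0.3 h to 4 h as the working figure.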

Compound 3, half-life: 0.1 h
Compound 3: the middle estimate sits 10-fold (1.00 log units) above what was measured; the measured number lies below the stated range.
By their numbers in this assay, from the lowest: compounds 3 and 1 (each within the scatter of the next); then compound 2.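

In this assay, 2-isopropoxyethyl in place of phenyl on an oxygen next to a carbonyl group gives a 1.2-fold lower number from compound 1 to compound 3 (0.07 log units; within the scatter) and so leaves compound 1 and compound 3 within the scatter of each other. Among these compounds, this is the first single-place reading at this position: an open chain with no ring and a six-membered aromatic ring of carbon only, each of 6 heavy atoms, are not told apart on this read-out. No measurement at hand explains this result.

Compound 2 at 1.07 h differs from compound 1 in more than one place, so the group behind its number stays unresolved. Also open, on these data alone, is how a carboxylic acid or an amide at this carbonyl, or a tert-butyl group on this oxygen, would read in this assay on the same core.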